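A few compounds are considered here, and "the series" means these few. Any claim that something is new, unique, unknown or untested is made for them only; others in the source may bear on it.

Measured so far: compound 1 `Cc1ccc(C(=O)Nc2ccc(CN3CCN(C)CC3)cc2)cc1-c1ccc2cn[nH]c2c1`, which in an assay on isolated protein for inhibition of Discoidin domain-containing receptor 2 (Homo sapiens), read by ELISA, with a stated time of 60 min (a higher number here means a weaker inhibitor, a lower number a stronger inhibitor), gives 6.7 nM; compound 2 `Cc1ccc(C(=O)Nc2cccc(C(F)(F)F)c2)cc1-c1ccc2c(-c3cnn(C)c3)n[nH]c2c1`, which in this assay gives 4.4 nM.

Compound 2 holds the lowest of the two numbers, but its gap to compound 1 lies within the usual scatter, so the two cannot be ranked. Compound 3 `Cc1ccc(C(=O)Nc2cccc(C(F)(F)F)c2)cc1-c1ccc2c(-c3cnn(C(C)C)c3)n[nH]c2c1` differs from compound 2 by isopropyl in place of methyl on an aromatic nitrogen. Among the compounds with values here, no measured pair shows this change, so in this assay no step beyond the scatter is expected in either direction. Compound 3 is therefore expected to give about 5 nM, between 2 nM and 15 nM. The expected step is a 1.1-fold higher number from compound 2 to compound 3 (0.06 log units; within the scatter), essentially none.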

Compound 3, half-maximal inhibitory concentration: 7.7 nM
Compound 3: middle estimate off by 1.5-fold (0.19 log units), on the low side; the measured number falls inside the stated range.
By their numbers in this assay, from the lowest: compounds 2, 1 and 3 (each within the scatter of the next).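

In this assay, the change from 1-methyl-1H-pyrazol-4-yl to 1-isopropyl-1H-pyrazol-4-yl gives a 1.8-fold higher number from compound 2 to compound 3 (0.24 log units; within the scatter), the first step read at this position. On this aromatic nitrogen, then, isopropyl and methyl cannot be told apart in this assay. Nothing available accounts for this result or tests it further.

The compounds shown leave open what a plain hydrogen on this nitrogen would give. They also leave open whether a cyclohexyl group, or a longer chain ending in an amine, would stay within the scatter of compound 2.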